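Replacing naphthalen-2-yl in compound 1: working notes

The source may hold more compounds than are shown below. What is called first, only, known or untested is meant among the compounds shown, and "the series" means these compounds.

Measured so far in a physicochemical assay for solubility, at pH 7; a lower number here means a less soluble compound, a higher number a more soluble compound:
- compound 1 `CN1CCC(C(=O)N2Cc3c(NC(=O)c4ccc5ccccc5c4)n[nH]c3C2(C)C)CC1`: 219000 nM
- compound 2 `CCN1CCC(C(=O)N2Cc3c(NC(=O)CC(C)C)n[nH]c3C2(C)C)CC1`: > 225000 nM (a limit)

For the measured compounds named here, compound 1 gives 219000 nM, the only actual number so far. Compound 2 has only a limit of the assay, > 225000 nM.

Compound 3 `CN1CCC(C(=O)N2Cc3c(NC(=O)Nc4cccc(F)c4)n[nH]c3C2(C)C)CC1` keeps the core of compound 1 and carries (3-fluorophenyl)amino in place of naphthalen-2-yl on a carbonyl carbon. Going by the values given here, no measured step covers this change, so the expectation is weakly founded. A small step down in this assay is expected, possibly none beyond the usual scatter, starting from compound 1 at 219000 nM. The expected move is a 1.3-fold lower number from compound 1 to compound 3 (0.11 log units; within the scatter). Compound 3 is estimated at 170000 nM, with an expected range of 80000 nM to 225000 nM.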

Compound 3, solubility: > 225000 nM
Compound 3 gave a limit, no number; the forecaster's own chance of this, stated with the estimate: 35%; middle value at least 1.3-fold (0.12 log units) from the limit.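

In this assay, compound 3 gives > 225000 nM, which is a limit and not a number. Putting (3-fluorophenyl)amino in place of naphthalen-2-yl on a carbonyl carbon can be read only as a floor, an at least 1.0-fold higher number from compound 1 to compound 3 (0.01 log units; that floor lies within the scatter), so the series now shows that this exchange gives no measured drop in the read-out. The true size of the step stays hidden, and compound 3 joins the values held at the ceiling: the limit of > 225000 nM in this assay, at which 2 of the 3 values shown sit.

Still open, going by these compounds, is how far compound 3 actually lies from compound 1, and whether any group at this position gives a clear drop in this assay. A biphenyl-4-yl group or a longer alkyl chain on the same carbonyl carbon would bear on that second question.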